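A few compounds are considered here, and "the series" means these few. Any claim that something is new, unique, unknown or untested is made for them only; others in the source may bear on it.

Measured so far in a functional assay on KARPAS-422 cells (Homo sapiens) for antiproliferative activity, read by resazurin assay, with a stated time of 72 h; a lower number here means a stronger inhibitor, a higher number a weaker inhibitor:
compound 1, `COC(c1cc(Cl)c2c(c1Cl)C(=O)N(Cc1c(C)cc(C)[nH]c1=O)CC2)C1CCOCC1`: 1150 nM; 19 nM (2 entries)
compound 2, `Cc1cc(C)c(CN2CCc3c(Cl)cc([C@@H](CO)[C@H]4CCCO4)c(Cl)c3C2=O)c(=O)[nH]1`: 535 nM
compound 3, `Cc1cc(C)c(CN2CCc3c(Cl)cc(C(CO)C4CCOC4)c(Cl)c3C2=O)c(=O)[nH]1`: 1040 nM; 17 nM (2 entries)

Among the measured compounds shown here, compound 2 stands at 535 nM in this assay, the only single number it has; two further entries for compound 2 give no single number. Compound 1 has two entries that lie far apart, (the several entries of compound 1 in this assay, 1150 nM; 19 nM (2 entries)), and compound 3 shows the same picture, (the several entries of compound 3 in this assay, 1040 nM; 17 nM (2 entries)), so the series as a whole covers a wide span.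

Compound 4, `Cc1cc(C)c(CN2CCc3c(Cl)cc([C@H](CO)[C@H]4CCCO4)c(Cl)c3C2=O)c(=O)[nH]1`, differs from compound 2 as follows: the two compounds have the same atoms and bonds and differ only in configuration as drawn: 1 of 2 stereo elements differ; a stereocentre at a saturated chain carbon is drawn S in compound 2 and R in compound 4. For the measured compounds named here, no measured pair separates compounds of this kind, so no size of step is known. Compounds differing only in configuration may differ strongly in this assay or not at all; the step expected here is a 2.7-fold lower number from compound 2 to compound 4 (0.43 log units; beyond the scatter), leaning toward a stronger inhibitor but with a range that also covers no change beyond the scatter. Compound 4 is estimated at 200 nM, between 20 nM and 2000 nM.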

Compound 4, half-maximal inhibitory concentration: 63 nM
Beside the measured number, compound 4's estimate is 3.2-fold (0.50 log units) above it; low and high end bracket the measured number.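

In this assay, changing the stereocentre at a saturated chain carbon from S to R gives an 8.5-fold lower number from compound 2 to compound 4 (0.93 log units; beyond the scatter), so this centre has a clear bearing on the read-out. The step can be assigned to that centre alone because nothing else separates the pair: the fact that compounds 2 and 4 differ only in the configuration as drawn.

As far as these compounds go, whether configuration also underlies the far-apart entries of compound 1 stays open: the several entries of compound 1 in this assay, 1150 nM; 19 nM (2 entries). Also open, from the compounds shown here alone, is whether the preference for R would hold with an amine or a carboxylic acid on this chain.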